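Swapping Phenoxy for Ethoxycarbonyl on a Shared Core

The source may hold more compounds than are shown below. What is called first, only, known or untested is meant among the compounds shown, and "the series" means these compounds.

Measured so far:
- compound 1, `O=C(COc1cc(=O)oc2cc(OCc3cccc(Cl)c3)ccc12)N1CCCCC1`: 9%
- compound 2, `O=c1cc(Oc2ccccc2)c2ccc(OCc3cccc(Cl)c3)cc2o1`: 0%

In an assay on isolated protein (strain Sprague-Dawley) for inhibition of Amine oxidase [flavin-containing] A (Rattus norvegicus), read by spectrophotometry, with a stated time of 5 min, tested at 10 uM (on this read-out lower numbers stand for less inhibition and higher numbers for more inhibition at the one concentration tested (going by the name of the read-out)), compound 2 gives 0%, the lowest of the two numbers. Its nearest neighbour is compound 1, whose value is 9%; the step of a number 9 percentage points lower from compound 1 to compound 2 (within the scatter) lies within the scatter, so the two compounds cannot be told apart on this read-out.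

Compound 3, `CCOC(=O)c1cc(=O)oc2cc(OCc3cccc(Cl)c3)ccc12`, has not yet been measured. It differs from compound 2 in one place: ethoxycarbonyl in place of phenoxy on an aromatic carbon. This puts a group with two hydrogen-bond acceptors and no ring where a ring-bearing phenoxy stood, on the aromatic carbon opposite the ring oxygen of the shared core.

Among the measured compounds shown here, no measured step in this assay bears directly on this exchange. For the measured compounds named here, the one step seen, from compound 1 to compound 2, changed a different attachment and stayed within the scatter, which suggests the core itself inhibits little regardless of what hangs on this oxygen. The expected step of a number 6 percentage points higher from compound 2 to compound 3 (within the scatter) is therefore none beyond the scatter. For compound 3 the estimate is 6%, with a range from 0% to 20%.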

Compound 3, a percentage reported as inhibition, at one concentration (the size of the read-out at that concentration, not a potency): 4.4%
For compound 3 the middle estimate is 1.6 percentage points above the measured one; the measured number falls inside the stated range.
By their numbers in this assay, from the lowest: compounds 2, 3 and 1 (each within the scatter of the next).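

In this assay the aromatic carbon opposite the ring oxygen has now carried three different groups, and exchanging them leaves the read-out unresolved. Ethoxycarbonyl in place of phenoxy gives a number 4.4 percentage points higher from compound 2 to compound 3 (within the scatter) and ethoxycarbonyl in place of ((piperidin-1-yl)carbonyl)methoxy gives a number 4.6 percentage points lower from compound 1 to compound 3 (within the scatter) so all three compounds stand within the scatter of one another, and the group without a ring cannot be told apart from the two that carry one. Nothing in the available data offers an explanation for why these three groups read alike.

With all three groups giving numbers that cannot be separated at the single concentration tested, the compounds shown do not reveal whether anything placed on this carbon can move inhibition beyond the scatter. An amine or a carboxylic acid at this place, or a longer chain ending in either, remains an open case, and so does whether exchanges elsewhere on the shared core would give a step that can be read.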